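A few compounds are considered here, and "the series" means these few. Any claim that something is new, unique, unknown or untested is made for them only; others in the source may bear on it.

In a functional assay on PC-12 cells (Rattus norvegicus) for inhibition, read by sulforhodamine B assay (on this read-out lower numbers stand for stronger inhibition and higher numbers for weaker inhibition), compound 1 (`O=C1N=C(O)S/C1=C\c1ccc(OCC2CCCCO2)cc1`) gives 22000 nM and compound 2 (`O=C1NC(=O)C(Cc2ccc(OCC3CCCCC3)cc2)S1`) gives 26000 nM while compound 3 (`O=C1NC(=O)/C(=C/c2ccc(OCC3CCC3)cc2)S1`) gives 13000 nM on the same scale. Compound 2 has the highest of these three numbers, yet it lies within the usual scatter of both others, so the three cannot be ranked. Compound 4 (`CCOc1ccc(CC2SC(=O)NC2=O)cc1`) differs from compound 2 as follows: methyl in place of cyclohexyl on a saturated chain carbon bound to an oxygen on an aromatic ring with methyl in place of cyclohexyl on a saturated chain carbon bound to an oxygen on an aromatic ring. Going by the values given here, no measured pair shows what such a swap does. The expected step is a 1.3-fold higher number from compound 2 to compound 4 (0.13 log units; within the scatter) and it is a small one toward weaker inhibition that may stay within the scatter. For compound 4 the estimate is 35000 nM with an expected range from 14000 nM to 90000 nM in this test.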

Compound 4, half-maximal inhibitory concentration: > 100000 nM
Compound 4 was reported as a limit; the forecaster's own chance of this, stated with the estimate: 20%; at least 2.8-fold (0.45 log units) between middle value and limit.
By their numbers in this assay, from the lowest: compounds 3, 1 and 2 (each within the scatter of the next). At a limit, above all of these: compound 4.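

In this assay compound 4 gives > 100000 nM, which is a limit of the assay and not a number. Putting methyl in place of cyclohexyl on a saturated chain carbon bound to an oxygen on an aromatic ring gives an at least 3.8-fold higher number from compound 2 to compound 4 (0.58 log units; beyond the scatter), the first single change shown here that goes beyond the scatter, so inhibition in this test depends on what sits at this place. The full size of the step stays unknown: the limit of > 100000 nM in this assay, at which 1 of the 4 values shown sits.

The compounds shown leave open what a phenyl ring, a longer chain such as butyl, or an amine would do at this place. They also leave open whether the same swap would act alike on the core of compound 3.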